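This account rests on a few compounds, and the source may have more. Where it says the series, first, only, none or still open, it means among the compounds named here.

In an ADME assay on HepG2 cells (Homo sapiens) for cytotoxicity, with a stated time of 72 h (a lower number here means that less compound is needed, a higher number that more compound is needed for the effect), compound 1 `O=C(Nc1ccc(-c2ccccc2)cc1)c1cc([N+](=O)[O-])ccc1Cl` gives > 27000 nM as a limit and not a number. Compound 2 `O=C(Nc1ccc(Cl)c(-c2nc3ccccc3s2)c1)c1cc([N+](=O)[O-])ccc1Cl` gives > 25000 nM as a limit as well. Compound 3 `COc1ccc(NC(=O)c2cc([N+](=O)[O-])ccc2Cl)cc1-c1nc2ccccc2s1` gives > 25000 nM as a limit too. Compound 2 therefore stands at the limit of > 25000 nM in this assay, at which 2 of the 3 values shown sit, and offers no number from which to start.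

The change to compound 4 `O=C(Nc1ccc(Cl)cc1)c1cc([N+](=O)[O-])ccc1Cl` is hydrogen in place of 1,3-benzothiazol-2-yl on an aromatic carbon and puts hydrogen in place of 1,3-benzothiazol-2-yl on an aromatic carbon. Going by the values given here, the only measured step from compound 2 is a step that the two limits leave unreadable from compound 2 to compound 3 and it swaps methoxy for chloro, so it gives no size to carry over to this change. With no readable step to go on, no step beyond the scatter is expected in this assay in either direction. The expected step is a step that the limit leaves unreadable from compound 2 to compound 4 and it remains an estimate. For compound 4 the estimated value is 30000 nM with an expected range from 12000 nM to 60000 nM in this assay and a report of a limit alone is the likeliest outcome.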

Compound 4, half-maximal effective concentration: > 27000 nM
Compound 4 was reported as a limit (the forecaster's own chance of this, stated with the estimate: 75%); the middle value does not contradict the limit.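

Compound 1, compound 2 and compound 4 all stand as limits, and the steps from compound 2 to compound 4 and from compound 1 to compound 4 cannot be read. The compounds shown leave open at what concentration any of them reaches the half-maximal effect in this assay.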